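Methoxycarbonyl in place of formyl on the shared core

A few compounds are considered here, and "the series" means these few. Any claim that something is new, unique, unknown or untested is made for them only; others in the source may bear on it.

Compound 3 `CS(=O)(=O)N1CC(CCl)c2cc(C=O)c(OCc3ccccc3)cc21` gives 3.24 ug/mL in a functional assay on KB cells (Homo sapiens), read by crystal violet staining (on this read-out lower numbers stand for stronger inhibition and higher numbers for weaker inhibition), the lowest of the three numbers, yet the gaps to compound 2 `CS(=O)(=O)N1CC(CCl)c2cc(Br)c(OCc3ccccc3)cc21` at 6.18 ug/mL and compound 1 `CS(=O)(=O)N1CC(CCl)c2ccc(OCc3ccccc3)cc21` at 6.32 ug/mL are within scatter, as the steps of a 1.9-fold lower number from compound 2 to compound 3 (0.28 log units; within the scatter) and a 2.0-fold lower number from compound 1 to compound 3 (0.29 log units; within the scatter) show. Compound 4 `COC(=O)c1cc2c(cc1OCc1ccccc1)N(S(C)(=O)=O)CC2CCl` differs from compound 3 by methoxy in place of hydrogen on a carbonyl carbon. Among the measured compounds shown here, the steps that bear on this change, a 1.0-fold lower number from compound 1 to compound 2 (0.01 log units; within the scatter), a 2.0-fold lower number from compound 1 to compound 3 (0.29 log units; within the scatter) and a 1.9-fold lower number from compound 2 to compound 3 (0.28 log units; within the scatter), all alter the same aromatic carbon and all stay within scatter. Compound 4 is therefore expected to show no step beyond the scatter, a 1.2-fold higher number from compound 3 to compound 4 (0.09 log units; within the scatter). The value of compound 4 in this assay is estimated at 4 ug/mL, within a range from 1.5 ug/mL to 10 ug/mL.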

Compound 4, half-maximal inhibitory concentration: 7.14 ug/mL
Compound 4: the middle estimate sits 1.8-fold (0.25 log units) below what was measured; the range from low to high includes it.
By their numbers in this assay, from the lowest: compounds 3, 2, 1 and 4 (each within the scatter of the next, the first and the last beyond it).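

In this assay, among the compounds shown here, methoxy in place of hydrogen on a carbonyl carbon gives the first step at this position that lies beyond the scatter, though a modest one (a 2.2-fold higher number from compound 3 to compound 4 (0.34 log units; beyond the scatter)). Methoxycarbonyl itself still stays within the scatter of both bromo (a 1.2-fold higher number from compound 2 to compound 4 (0.06 log units; within the scatter)) and hydrogen (a 1.1-fold higher number from compound 1 to compound 4 (0.05 log units; within the scatter)) on the aromatic carbon, so only the formyl and methoxycarbonyl compounds stand apart. No measurement shown here accounts for this step. On these data alone, how an amine or a carboxylic acid on that aromatic carbon would compare remains open.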